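This account rests on a few compounds, and the source may have more. Where it says the series, first, only, none or still open, it means among the compounds named here.

Compound 1 `CCCCCCc1nc(N)n(CC(=O)Nc2ccccc2)c1-c1ccccc1Br`, compound 2 `Nc1nc(CC2CCCC2)c(-c2ccccc2Br)n1CC(=O)Nc1ccccc1` and compound 3 `CCCCCCc1nc(N)n(CC(=O)Nc2ccc(C)cc2)c1-c1ccccc1Br` share one core and differ in two places. In a functional assay on MIA PaCa-2 cells (Homo sapiens) for antiproliferative activity, read by MTT assay, with a stated time of 48 h (a higher number here means a weaker inhibitor, a lower number a stronger inhibitor), compound 1 gives 8600 nM, compound 2 gives 61400 nM and compound 3 gives 6500 nM. The step of a 7.1-fold higher number from compound 1 to compound 2 (0.85 log units; beyond the scatter) is a clear weakening, while the step of a 1.3-fold lower number from compound 1 to compound 3 (0.12 log units; within the scatter) stays within the scatter. Compound 3 therefore has the lowest number of the three, though compound 1 sits within the scatter of it. Compound 4 `COc1ccc(Cc2nc(N)n(CC(=O)Nc3ccc(C)cc3)c2-c2ccccc2Br)cc1` carries 4-methoxyphenyl in place of pentyl on a saturated chain carbon bound to an aromatic carbon. Among the measured compounds shown here, the only measured step at that place, a 7.1-fold higher number from compound 1 to compound 2 (0.85 log units; beyond the scatter), exchanged the pentyl chain for a ring and weakened inhibition, so a weakening is expected here too, a 2.8-fold higher number from compound 3 to compound 4 (0.44 log units; beyond the scatter). Compound 4 is estimated at 18000 nM, with a range from 5000 nM to 65000 nM.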

Compound 4, half-maximal inhibitory concentration: 5200 nM
Beside the measured number, compound 4's estimate is 3.5-fold (0.54 log units) above it; the range from low to high includes it.
By their numbers in this assay, from the lowest: compounds 4, 3 and 1 (each within the scatter of the next); then compound 2.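

In this assay the exchange of pentyl for 4-methoxyphenyl gives a 1.3-fold lower number from compound 3 to compound 4 (0.10 log units; within the scatter) and shows that this position can carry an aromatic ring without a clear loss. The earlier ring exchange to cyclopentyl gave a 7.1-fold higher number from compound 1 to compound 2 (0.85 log units; beyond the scatter) on a different partner compound, so a ring here does not always weaken inhibition. Nothing available explains why these two steps differ. Still open, going by these compounds, is whether a plain phenyl would behave like 4-methoxyphenyl here. Also open, on these data alone, is how an amine or a carboxylic acid at this position would read.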